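The source may hold more compounds than are shown below. What is called first, only, known or untested is meant among the compounds shown, and "the series" means these compounds.

Measured so far:
compound 1 `COc1ccc(-c2nnc(NC(=O)/C=C/c3ccccc3)s2)cc1`: 0.78 ug/mL
compound 2 `Cc1ccc(-c2nnc(NC(=O)/C=C/c3ccc(C(F)(F)F)cc3)s2)cc1`: 1.1 ug/mL

Both numbers come from a functional assay on MCF7 cells (Homo sapiens) for antiproliferative activity, read by MTT assay, with a stated time of 48 h; on this read-out higher numbers stand for weaker inhibition and lower numbers for stronger inhibition. Compound 1 holds the lower of the two, but compound 2 lies within the scatter of it, so no order between the two can be read. Compound 3 `O=C(/C=C/c1ccccc1)Nc1nnc(-c2ccc(Cl)cc2)s1` is not yet measured. It differs from compound 1 by chloro in place of methoxy on an aromatic carbon. Among the measured compounds shown here, no measured pair shows this change, so nothing here fixes a step size; the step of a 1.2-fold higher number from compound 1 to compound 3 (0.06 log units; within the scatter) is expected to stay within the scatter, in no set direction. Compound 3 is expected at 0.9 ug/mL in this assay, with a range from 0.4 ug/mL to 2 ug/mL.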

Compound 3, half-maximal inhibitory concentration: 1.42 ug/mL
Compound 3: the middle estimate sits 1.6-fold (0.20 log units) below what was measured, within the range that was stated.
By their numbers in this assay, from the lowest: compounds 1, 2 and 3 (each within the scatter of the next).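

Chloro in place of methoxy, para to a large group, gives the first one-place step in the series: in this assay the change is a 1.8-fold higher number from compound 1 to compound 3 (0.26 log units; within the scatter). This place therefore tolerates the replacement of 4-methoxyphenyl by 4-chlorophenyl without a readable change in this read-out. Nothing available accounts for the size of this step.

From the compounds shown here alone, whether an amine or a carboxylic acid on this aromatic carbon would give a step beyond the scatter remains open. So does the outcome of a trifluoromethyl change on the other aromatic ring made alone, with the rest of compound 1 held fixed.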